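Longer end chain on the second core: expected dose

The source may report more compounds than this note shows. Statements on the series, on what has been measured and on what is new or still open speak of the compounds shown alone.

Compound 1 `N=C(S)CCCn1nc(-c2ccccc2)ccc1=O` and compound 2 `N=C(S)CCCCCCn1nc(-c2ccccc2)ccc1=O` share one core; compound 3 `N=C(S)CCN1N=C(c2ccccc2)CCC1=O` and compound 4 `N=C(S)CCCCCN1N=C(c2ccccc2)CCC1=O` share another, and the difference between the two cores is not broken down here. In a functional assay on the whole organism (stomach) with Rattus norvegicus as the target (a higher number here means that more compound is needed for the effect, a lower number that less compound is needed), compound 1 gives 31.9 mg/kg. For compound 2 only a limit is known in this assay, namely > 100 mg/kg. The change from compound 1 to compound 2 is a group of 6 heavy atoms (4 carbon, 1 nitrogen, 1 sulfur; no ring) in place of a group of 3 heavy atoms (1 carbon, 1 nitrogen, 1 sulfur; no ring), on a saturated chain carbon, three bonds along the chain from an aromatic nitrogen, and it gave an at least 3.1-fold higher number from compound 1 to compound 2 (0.49 log units; beyond the scatter), a step that ends at the limit of > 100 mg/kg in this assay, at which 2 of the 3 values shown sit. For compound 3 also only a limit is known in this assay, namely > 100 mg/kg. The change to compound 4 is a group of 6 heavy atoms (4 carbon, 1 nitrogen, 1 sulfur; no ring) in place of a group of 3 heavy atoms (1 carbon, 1 nitrogen, 1 sulfur; no ring), on a saturated chain carbon, two bonds along the chain from an amide-type nitrogen in a ring; the place differs, three bonds along the chain from an aromatic nitrogen against two bonds along the chain from an amide-type nitrogen in a ring, so it is the same kind of change, not the same. Compound 4 is expected to show a step that the limit leaves unreadable from compound 3 to compound 4. The estimate for compound 4 is 250 mg/kg, between 100 mg/kg and 600 mg/kg, expected because the like change gave an at least 3.1-fold higher number from compound 1 to compound 2 (0.49 log units; beyond the scatter).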

Compound 4, dose for half-maximal effect: 100 mg/kg
Compound 4: middle estimate off by 2.5-fold (0.40 log units), on the high side; the range from low to high includes it.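

In this assay compound 3 stands at a limit of the assay, > 100 mg/kg, so the size of its step to compound 4 cannot be read. Carried to the second core, the change gives a number no higher from compound 3 to compound 4 (the limit leaves the size open) and does not repeat the rise in the number seen on the core of compound 1, although its place on the chain also differs: the same change on two cores in this assay, an at least 3.1-fold higher number (0.49 log units; beyond the scatter) from compound 1 to compound 2 and a number no higher (the limit leaves the size open) from compound 3 to compound 4, at least 3.1-fold (0.49 log units) apart, beyond the scatter of two such steps. This holds for these two pairs only, and it does not show whether the difference belongs to the core or to the place, nor how large the step on the second core is: the limit of > 100 mg/kg in this assay, at which 2 of the 4 values shown sit.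

Open, as far as these compounds go, is how a longer chain on the core of compound 3 would read in this assay. Also open, from the compounds shown here alone, is whether an amine or a carboxylic acid in place of the end group would behave alike on both cores.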